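Swapping the benzyl ring after the reactive amide is removed

The compounds below may be only part of what the source reports. "The series", "measured", "known", "first", "only" and "open" are said of these compounds alone.

Measured compounds:
compound 1 `C=C(Br)C(=O)Nc1cccc(/C=C2\SC(=O)N(Cc3ccc(C)cc3)C2=O)c1` — 600 nM
compound 2 `C=C(Br)C(=O)Nc1cccc(/C=C2\SC(=O)N(Cc3cccc(F)c3)C2=O)c1` — 590 nM
compound 3 `Cc1ccc(CN2C(=O)S/C(=C\c3cccc(N)c3)C2=O)cc1` — 176000 nM

All three were tested in a functional assay on L1210 cells (Mus musculus) for cytotoxicity, read by cell counting, with a stated time of 2 days; on this read-out higher numbers stand for weaker inhibition and lower numbers for stronger inhibition. Compound 1 and compound 2 differ by 3-fluorophenyl in place of 4-methylphenyl on a saturated chain carbon bound to an amide-type nitrogen in a ring, and this change made a step of a 1.0-fold lower number from compound 1 to compound 2 (0.01 log units; within the scatter), so the two values cannot be told apart. Compound 3 differs from compound 1 by hydrogen in place of (1-bromoethenyl)carbonyl on a nitrogen on an aromatic ring, and here the step was a 290-fold higher number from compound 1 to compound 3 (2.47 log units; beyond the scatter), a large loss of potency.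

Compound 4 `Nc1cccc(/C=C2\SC(=O)N(Cc3cccc(F)c3)C2=O)c1` has not yet been measured. It stands to compound 3 exactly as compound 2 stands to compound 1: the change is 3-fluorophenyl in place of 4-methylphenyl on a saturated chain carbon bound to an amide-type nitrogen in a ring, the same change at the same place. Because the earlier step was a 1.0-fold lower number from compound 1 to compound 2 (0.01 log units; within the scatter), the step from compound 3 to compound 4 is expected to be about a 1.0-fold lower number from compound 3 to compound 4 (0.02 log units; within the scatter). Compound 4 is therefore estimated at 170000 nM, most likely between 80000 nM and 400000 nM.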

Compound 4, half-maximal inhibitory concentration: 199000 nM
Beside the measured number, compound 4's estimate is 1.2-fold (0.07 log units) below it; low and high end bracket the measured number.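

In this assay, 3-fluorophenyl in place of 4-methylphenyl gave a 1.1-fold higher number from compound 3 to compound 4 (0.05 log units; within the scatter), so this swap left the number unchanged within the scatter on both cores: the same change on two cores in this assay, a 1.0-fold lower number (0.01 log units; within the scatter) from compound 1 to compound 2 and a 1.1-fold higher number (0.05 log units; within the scatter) from compound 3 to compound 4, 1.1-fold (0.06 log units) apart, within the scatter of two such steps. Hydrogen in place of (1-bromoethenyl)carbonyl gave a 340-fold higher number from compound 2 to compound 4 (2.53 log units; beyond the scatter), so the large loss of potency also carried over from one core to the other: the same change on two cores in this assay, a 290-fold higher number (2.47 log units; beyond the scatter) from compound 1 to compound 3 and a 340-fold higher number (2.53 log units; beyond the scatter) from compound 2 to compound 4, 1.1-fold (0.06 log units) apart, within the scatter of two such steps. This shows that the two changes transferred between these compounds in this one cell assay, but it does not show that they would transfer to other cores, or why the number shifts so far.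

Open, as far as these compounds go, is whether a simple acetyl group on that nitrogen would keep the potency of compound 1. Also open, from the compounds shown here alone, is whether an amine or a carboxylic acid on the phenyl ring would leave the number as unchanged as the swap did.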